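An Amide in Place of an Aldehyde on the Ring

The source may hold more compounds than are shown below. What is called first, only, known or untested is meant among the compounds shown, and "the series" means these compounds.

Of the compounds shown here, three from one series have been tested in a functional assay on MCF7 cells (Homo sapiens) for antiproliferative activity, read by MTT assay, with a stated time of 48 h; on this read-out higher numbers stand for weaker inhibition and lower numbers for stronger inhibition. Compound 1 `CC(=O)O[C@]1(C)/C=C/C(=O)/C(CO)=C\C[C@](C)(CCC=C(C)C)/C=C/[C@H]1OC(=O)C=C(C)C` gives 2320 nM. Within the data shown here, compound 2 `CO[C@]1(C)/C=C/C(=O)/C(CO)=C\C[C@](C)(CCC=C(C)C)/C=C/[C@H]1OC(=O)C=C(C)C` gives 14300 nM, and the only single-point step so far is a 6.2-fold higher number from compound 1 to compound 2 (0.79 log units; beyond the scatter). Compound 3 `CC(C)=CCC[C@]1(C)/C=C/[C@@H](OC(=O)C=C(C)C)[C@](C)(O)/C=C/C(=O)/C(C=O)=C\C1` gives 12600 nM; its number lies within the scatter of that of compound 2 and is beyond the scatter above that of compound 1, so on the numbers shown compound 3 sits at the weaker end of the three.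

Compound 4 `CCN(CC)C(=O)/C1=C/C[C@](C)(CCC=C(C)C)/C=C/[C@@H](OC(=O)C=C(C)C)[C@](C)(O)/C=C/C1=O` carries the change (diethylamino in place of hydrogen on a carbonyl carbon). Among the measured compounds shown here, the step from compound 1 to compound 2 touches a different part of the molecule and gives no guide to an exchange on the carbonyl carbon; no measured pair bears on the change from formyl to diethylcarbamoyl. Whether the switch strengthens or weakens inhibition in this assay therefore cannot be read from the data, and the expectation must be wide. Compound 4 is expected to give about 18000 nM, with a range from 5000 nM to 60000 nM. The estimated step is a 1.4-fold higher number from compound 3 to compound 4 (0.15 log units; within the scatter), which is taken to be within the scatter.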

Compound 4, half-maximal inhibitory concentration: 12100 nM
For compound 4 the middle estimate is 1.5-fold (0.17 log units) above the measured one; measured number inside the range.
By their numbers in this assay, from the lowest: compound 1; then compounds 4, 3 and 2 (each within the scatter of the next).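

In this assay the exchange of formyl for diethylcarbamoyl gives a 1.0-fold lower number from compound 3 to compound 4 (0.02 log units; within the scatter) and so leaves the two compounds indistinguishable on this read-out. Among these compounds, this is the first measured pair to bear on this carbonyl carbon, and it shows that diethylamino, with its 5 heavy atoms, can stand in place of a single hydrogen there without the number moving beyond the usual scatter. Nothing available explains why the aldehyde and the amide give matching numbers.

On these data alone, a single pair cannot show whether this match holds for amides in general, so it remains open whether a plain amino group, dimethylamino or a ring amine such as piperidine in place of diethylamino would give a similar number. As far as these compounds go, it also remains open whether a carboxylic acid or an ester on this carbonyl carbon would leave the number where it is or move it, and whether the match would persist on a compound that carries an acetyl group in place of the hydrogen on the tertiary hydroxyl oxygen.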